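The source may hold more compounds than are shown below. What is called first, only, known or untested is meant among the compounds shown, and "the series" means these compounds.

Measured so far in a functional assay on DWD cells (Homo sapiens) for inhibition, read by sulforhodamine B assay; on this read-out lower numbers stand for stronger inhibition of growth and higher numbers for weaker inhibition of growth:

- Compound 1 `COc1cc(-c2ccc(-c3ccc(-c4nc5cc(C)ccc5[nH]4)cc3)cc2)cc(OC)c1OC`: 170 nM
- Compound 2 `COc1ccc(-c2ccc(-c3ccc(-c4nc5c(O)cccc5[nH]4)cc3)cc2)cc1OC`: 1400 nM

Of these two, compound 2 has the higher number, so it inhibits growth more weakly, and its gap to compound 1 lies beyond the usual scatter of repeated measurements.

Compound 3 `COc1cc(-c2ccc(-c3ccc(-c4nc5c(O)cccc5[nH]4)cc3)cc2)cc(OC)c1OC` has not yet been measured. It is built from compound 2 by one change, methoxy in place of hydrogen on an aromatic carbon. This gives compound 3 the same methoxy-bearing end as compound 1, which reads 170 nM in this assay. Compound 1 and compound 2 also differ elsewhere, so their gap cannot be credited to this change alone, and only part of it is expected to carry over. A moderate shift towards a lower number is therefore expected, with stronger inhibition of growth as the likely direction, though the two measured compounds give only thin support.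

The estimated value for compound 3 is 550 nM, with an expected range from 170 nM to 1600 nM. This estimate means an expected 2.5-fold lower number from compound 2 to compound 3 (0.41 log units; beyond the scatter).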

Compound 3, concentration for 50% growth inhibition: 190 nM
Compound 3: middle estimate off by 2.9-fold (0.46 log units), on the high side; the measured number falls inside the stated range.
By their numbers in this assay, from the lowest: compounds 1 and 3 (each within the scatter of the next); then compound 2.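

In this assay this position clearly matters: placing methoxy instead of hydrogen on the aromatic carbon, ortho to one methoxy group and meta to another, gives a 7.4-fold lower number from compound 2 to compound 3 (0.87 log units; beyond the scatter) and so moves growth inhibition by more than the usual scatter of repeat measurements. The earlier pair could not show this on its own, as compound 1 and compound 2 differ in more than one place. With the methoxy end held the same, the change at the other end of the molecule, 4-hydroxy-1H-benzimidazol-2-yl in place of 5-methyl-1H-benzimidazol-2-yl, gives a 1.1-fold higher number from compound 1 to compound 3 (0.05 log units; within the scatter) and stays within the scatter, so these two groups cannot be told apart here, and nothing measured explains why the added methoxy has the effect it has.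

The compounds shown leave open whether an ethoxy group or an amine at the same position would produce a step of similar size. They also leave open whether hydrogen at this position would cost as much alongside 5-methyl-1H-benzimidazol-2-yl as it does alongside 4-hydroxy-1H-benzimidazol-2-yl, and how a carboxylic acid on that end would read.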